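From a methoxy to a hydroxy on a shared core

This account rests on a few compounds, and the source may have more. Where it says the series, first, only, none or still open, it means among the compounds named here.

Compound 2 `COc1cc(C)cc(-c2nn(CC#N)cc2-c2ccnc(-c3ccc(N(C)C)cc3)c2)c1` gives -61% in a functional assay on NCI-H522 cells (Homo sapiens) for cytotoxicity, read by sulforhodamine B assay, with a stated time of 48 h, tested at 1 uM (on this read-out higher numbers stand for a weaker effect at the one concentration tested and lower numbers for a stronger effect), the lowest of the two numbers recorded, while compound 1 `Cc1cc(O)cc(-c2nn(CC#N)cc2-c2ccnc(-c3ccc(Oc4ccccc4)cc3)c2)c1` gives 2%, a gap beyond the scatter. Compound 3 `Cc1cc(O)cc(-c2nn(CC#N)cc2-c2ccnc(-c3ccc(N(C)C)cc3)c2)c1` is not yet measured and differs from compound 2 by a single change: hydrogen in place of methyl on an oxygen on an aromatic ring. Among the compounds with values here, with no measured pair showing this exchange, only a modest step is expected from compound 2 to compound 3 in this assay, likely upward or none beyond the scatter, namely a number 16 percentage points higher from compound 2 to compound 3 (beyond the scatter). Compound 3 is therefore estimated at -45%, within -80% to 0%.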

Compound 3, a percentage reported as activity, at one concentration (the size of the read-out at that concentration, not a potency): -13%
The estimate for compound 3 lay 32 percentage points below the measured number; measured number inside the range.
By their numbers in this assay, from the lowest: compound 2; then compound 3; then compound 1.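

In this assay, the methyl on this oxygen proves to matter: hydroxy in place of methoxy gives a number 48 percentage points higher from compound 2 to compound 3 (beyond the scatter), a clear loss of effect. With the hydroxy held constant, dimethylamino in place of phenoxy gives a number 15 percentage points lower from compound 1 to compound 3 (beyond the scatter), so that exchange also alters the effect, though only modestly. Nothing available explains either step. On these data alone, whether ethoxy or an amine at this place would preserve the effect remains open, as does whether methoxy would bring the same gain alongside the phenoxy group of compound 1.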